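Sulfonamide in place of acetamide on a shared anilide core

The compounds below may be only part of what the source reports. "The series", "measured", "known", "first", "only" and "open" are said of these compounds alone.

Compound 1, `CN(C)c1ccc(C(=O)Nc2cccc(NC(=O)COc3ccc4c(c3)CCC(=O)N4)c2)cc1`, gives 9970 nM in an assay on isolated protein for inhibition of Rho-associated protein kinase 2 (Homo sapiens), read by scintillation counting, radiometric assay and 33P incorporation, with a stated time of 40 min, in the presence of a further agent that is not named here; on this read-out higher numbers stand for weaker inhibition and lower numbers for stronger inhibition. Compound 2, `CC(=O)Nc1cccc(NC(=O)COc2ccc3c(=O)ccoc3c2)c1`, gives 136 nM. Compound 3, `CCCc1ccc(C(=O)Nc2cccc(NC(=O)COc3ccc4c(=O)ccoc4c3)c2)cc1`, gives 14 nM.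

Among these three numbers compound 2 stands second highest; compound 3 lies nearest to it and compound 1 furthest. Compound 4, `Cn1ccc(S(=O)(=O)Nc2cccc(NC(=O)COc3ccc4c(=O)ccoc4c3)c2)n1`, differs from compound 2 in one place: a group of 9 heavy atoms (4 carbon, 2 nitrogen, 2 oxygen, 1 sulfur; one five-membered aromatic ring with 2 hetero atoms) in place of a group of 3 heavy atoms (2 carbon, 1 oxygen; no ring), on a nitrogen on an aromatic ring. Among the compounds with values here, the one measured step that bears on this is a 9.7-fold lower number from compound 2 to compound 3 (0.99 log units; beyond the scatter), where a larger group on the same carbonyl carbon brought a modest gain beyond the scatter. The entering group in compound 4 is likewise larger than acetyl, though it carries a sulfur rather than a carbonyl, so a smaller gain is expected, a 2.3-fold lower number from compound 2 to compound 4 (0.36 log units; beyond the scatter). Compound 4 is therefore estimated at 60 nM, with a range from 15 nM to 250 nM.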

Compound 4, half-maximal inhibitory concentration: 1350 nM
For compound 4 the middle estimate is 23-fold (1.35 log units) below the measured one, outside the stated range (above it).
By their numbers in this assay, from the lowest: compound 3; then compound 2; then compound 4; then compound 1.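

In this assay a larger group on this nitrogen does not by itself bring a gain, as a 9.9-fold higher number from compound 2 to compound 4 (1.00 log units; beyond the scatter) runs opposite in direction to a 9.7-fold lower number from compound 2 to compound 3 (0.99 log units; beyond the scatter). Exchanging the 4-propylphenyl-bearing acyl group for the entering group costs more, with a 96-fold higher number from compound 3 to compound 4 (1.98 log units; beyond the scatter) on the same core. Nothing measured here accounts for this loss.

The compounds shown do not separate the sulfonyl link from the five-membered ring, since the two change together. A methanesulfonyl group on the same nitrogen, or the same ring joined through a carbonyl, would tell them apart.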